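Compound 4: 4-hydroxycyclohexyl in place of benzyl

This account rests on a few compounds, and the source may have more. Where it says the series, first, only, none or still open, it means among the compounds named here.

Compound 3 `O=C(NCCNS(=O)(=O)c1ccc(-c2ccccc2OCc2ccccc2)s1)Nc1cc(Cl)cc(Cl)c1` gives > 20000 nM in a functional assay on HeLa cells (Homo sapiens) for inhibition, read by CCK-8 assay, with a stated time of 48 h (a lower number here means a stronger inhibitor, a higher number a weaker inhibitor), which is a limit and not a number. Compound 1 `O=C(NCCNS(=O)(=O)c1ccc(-c2ccccc2OCc2cccc(O)c2)s1)Nc1cc(Cl)cc(Cl)c1` gives > 50000 nM, also a limit. Compound 2 `O=C(NCCNS(=O)(=O)c1ccc(-c2ccccc2Oc2ccc(O)c(O)c2)s1)Nc1cc(Cl)cc(Cl)c1` gives > 20000 nM, again a limit. Within the data shown here, compound 3 therefore has no numeric position, and the series so far sits only at limits (the limit of > 20000 nM in this assay, at which 2 of the 3 values shown sit; (the limit of > 50000 nM in this assay, at which 1 of the 3 values shown sits)).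

Compound 4 `O=C(NCCNS(=O)(=O)c1ccc(-c2ccccc2O[C@H]2CC[C@H](O)CC2)s1)Nc1cc(Cl)cc(Cl)c1` carries one change, 4-hydroxycyclohexyl in place of benzyl on an oxygen on an aromatic ring.

The measured steps that bear on this all alter the group on that oxygen: a step that the two limits leave unreadable from compound 2 to compound 3, a step that the two limits leave unreadable from compound 1 to compound 3 and a step that the two limits leave unreadable from compound 1 to compound 2. None has a readable size, so they give no direction and no magnitude for the new group. The working expectation is no step beyond the scatter in this assay, with compound 4 most likely also reported as a limit.

The expected change is a step that the limit leaves unreadable from compound 3 to compound 4, with no direction favoured. For compound 4 the estimate is 30000 nM, with an expected range from 12000 nM to 70000 nM.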

Compound 4, half-maximal inhibitory concentration: > 20000 nM
Compound 4 gave a limit, no number; the forecaster's own chance of this, stated with the estimate: 80%; the middle value does not contradict the limit.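

Compound 4 gives > 20000 nM in this assay, which is a limit. Its steps from compound 1, compound 2 and compound 3 cannot be read. The compounds shown leave open whether any group on that oxygen gives a numeric value in this assay.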